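The source may report more compounds than this note shows. Statements on the series, on what has been measured and on what is new or still open speak of the compounds shown alone.

Measured so far in a functional assay on SK-OV-3 cells (Homo sapiens) for inhibition, read by CCK-8 assay, with a stated time of 70 h; on this read-out higher numbers stand for weaker inhibition and lower numbers for stronger inhibition:
compound 1, `COc1ccc(COc2ccc(OCCOCCNC3CCCC3)cc2)cc1` — 15700 nM
compound 2, `O=[N+]([O-])c1ccccc1COc1ccc(OCCOCCNC2CCCCC2)cc1` — 2880 nM

Compound 1 holds the highest of the two numbers. Compound 2 sits at a lower number, and that gap lies beyond the usual scatter, but the two structures differ in more than one place, so the gap is not assigned to any single change. Compound 3, `COC(=O)c1cccc(COc2ccc(OCCOCCNC3CCCC3)cc2)c1`, differs from compound 1 in one place: 3-(methoxycarbonyl)phenyl in place of 4-methoxyphenyl on a saturated chain carbon bound to an oxygen on an aromatic ring. Within the data shown here, no measured pair follows that change on its own, so the expected size of the step in this assay rests only on the spread of the two numbers already in hand. Compound 1 gives 15700 nM, and compound 2 shows that a lower number is reachable within this series, so the step from compound 1 to compound 3 is expected to be modest and downward, though a step within the scatter is nearly as plausible. Compound 3 is expected near 8000 nM, within 3000 nM to 22000 nM. That estimate amounts to a 2.0-fold lower number from compound 1 to compound 3 (0.29 log units; within the scatter).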

Compound 3, half-maximal inhibitory concentration: 45500 nM
Estimate against measurement, compound 3: 5.7-fold (0.75 log units) below; measured number above the stated range.
By their numbers in this assay, from the lowest: compound 2; then compound 1; then compound 3.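

In this assay, among these compounds, the change gives a 2.9-fold higher number from compound 1 to compound 3 (0.46 log units; beyond the scatter) and this is the first step that can be read at a single place. It shows that the group on a saturated chain carbon bound to an oxygen on an aromatic ring is not indifferent to exchange, and that moving from 4-methoxyphenyl to 3-(methoxycarbonyl)phenyl on the shared core goes toward weaker inhibition by more than the scatter. No measurement of any property of these groups bears on this step, so it stands as an observation without an explanation.

The single step changes both the substituent and its number on the ring, so the compounds shown leave open which of the two goes with the weaker inhibition. Also open, going by these compounds, is whether a plain phenyl group, or a phenyl group carrying a carboxylic acid or a primary amide in place of the methoxycarbonyl group, would keep the number of compound 1 or move it further in either direction.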